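Adding a Further Sulfo Group to Compound 2

The compounds below may be only part of what the source reports. "The series", "measured", "known", "first", "only" and "open" are said of these compounds alone.

Compound 2 `CC(=O)N[C@H]1[C@@H](OC[C@@H](O)[C@@H](O)[C@H](O)[C@@H](O)CNc2cccc(NC(=O)CCCCC3CCSS3)c2)O[C@H](CO)[C@H](OS(=O)(=O)O)[C@@H]1O[C@@H]1O[C@H](C(=O)O)[C@@H](O)[C@H](O)[C@H]1OS(=O)(=O)O` gives 41 nM in an assay on isolated protein for binding affinity to fibroblast growth factor 2 (Homo sapiens), read by surface plasmon resonance (on this read-out lower numbers stand for tighter binding and higher numbers for weaker binding), the lower of the two numbers available, although compound 1 `CC(=O)N[C@H]1[C@@H](OC[C@@H](O)[C@@H](O)[C@H](O)[C@@H](O)CNc2cccc(NC(=O)CCCCC3CCSS3)c2)O[C@H](CO)[C@H](O)[C@@H]1O[C@@H]1O[C@H](C(=O)O)[C@@H](O)[C@H](O)[C@H]1OS(=O)(=O)O`, which gives 62 nM, lies within the usual scatter of it. Compound 3 `CC(=O)N[C@H]1[C@@H](OC[C@@H](O)[C@@H](O)[C@H](O)[C@@H](O)CNc2cccc(NC(=O)CCCCC3CCSS3)c2)O[C@H](CO)[C@H](OS(=O)(=O)O)[C@@H]1O[C@@H]1O[C@H](C(=O)O)[C@@H](O)[C@H](OS(=O)(=O)O)[C@H]1OS(=O)(=O)O` differs from compound 2 by one change: sulfo in place of hydrogen on an oxygen on a saturated carbon. Among the measured compounds shown here, the only step of the same kind, a 1.5-fold lower number from compound 1 to compound 2 (0.18 log units; within the scatter), stayed inside the scatter. A similar outcome is therefore expected, at most a small shift toward tighter binding, so the estimated step is a 1.4-fold lower number from compound 2 to compound 3 (0.14 log units; within the scatter). Compound 3 is expected to give 30 nM, within a range from 12 nM to 80 nM.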

Compound 3, dissociation constant: 52 nM
The estimate for compound 3 lay 1.7-fold (0.24 log units) below the measured number; the range from low to high includes it.
By their numbers in this assay, from the lowest: compounds 2, 3 and 1 (each within the scatter of the next).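

Hydroxy to sulfooxy at this further place gives a 1.3-fold higher number from compound 2 to compound 3 (0.10 log units; within the scatter) in this assay and so, like a 1.5-fold lower number from compound 1 to compound 2 (0.18 log units; within the scatter) at the other place, leaves the number inside the scatter. Among the compounds shown here, a second place therefore now shows this same outcome for the change, where the earlier compounds offered only one. Nothing available bears on the reason for this result. As far as these compounds go, whether an amine or a carboxylic acid in place of the sulfooxy group would move the number beyond the scatter remains open.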